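The source may hold more compounds than are shown below. What is called first, only, known or untested is meant among the compounds shown, and "the series" means these compounds.

Four compounds share one core and differ only in an outer group. Compound 2 `CCOC(=O)C1=Cc2ccccc2OC1(OCc1cn(CC(=O)Nc2ccccc2F)nn1)C(F)(F)F` is the sole one with a plain number in a functional assay on MCF7 cells (Homo sapiens) for inhibition, read by MTT assay, with a stated time of 24 h (a lower number here means a stronger inhibitor, a higher number a weaker inhibitor), where compound 2 gives 42100 nM. Compound 1 `CCOC(=O)C1=Cc2ccccc2OC1(OCc1cn(CC(=O)Nc2ccccc2Br)nn1)C(F)(F)F` reaches only the assay limit of > 150000 nM. Compound 3 `CCOC(=O)C1=Cc2ccccc2OC1(OCc1cc(-c2ccc(Br)cc2)no1)C(F)(F)F` likewise reaches only the assay limit of > 150000 nM. Among the measured compounds shown here, the one measured step, an at least 3.5-fold lower number from compound 1 to compound 2 (0.55 log units; beyond the scatter), ran from bromo to fluoro, and its size is bounded by the limit of > 150000 nM in this assay, at which 2 of the 3 values shown sit. Compound 4 `CCOC(=O)C1=Cc2ccccc2OC1(OCc1cn(CC(=O)Nc2ccc(I)cc2Cl)nn1)C(F)(F)F` changes the same place the other way: 2-chloro-4-iodophenyl in place of 2-fluorophenyl on an amide-type nitrogen. Because an at least 3.5-fold lower number from compound 1 to compound 2 (0.55 log units; beyond the scatter) favoured fluoro over bromo, compound 4 is expected to weaken, a 2.9-fold higher number from compound 2 to compound 4 (0.45 log units; beyond the scatter). Compound 4 is therefore estimated at 120000 nM, within 30000 nM to 500000 nM, quite possibly again only a limit.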

Compound 4, half-maximal inhibitory concentration: 28100 nM
Compound 4: the middle estimate sits 4.3-fold (0.63 log units) above what was measured, outside the stated range (below it).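

In this assay, 2-chloro-4-iodophenyl in place of 2-fluorophenyl on the amide-type nitrogen gives a 1.5-fold lower number from compound 2 to compound 4 (0.18 log units; within the scatter), so this position tolerates this change without a measurable loss, and the earlier bromo-to-fluoro step does not extend into a rule against every larger halogen pattern. The same position also gives an at least 5.3-fold lower number from compound 1 to compound 4 (0.72 log units; beyond the scatter), which sets 2-bromophenyl apart from both other groups. That step has only a bound for its size, as compound 1 sits at a limit: the limit of > 150000 nM in this assay, at which 2 of the 4 values shown sit.

Still open, on these data alone, is which of the chloro and iodo groups matters in compound 4. Also open, as far as these compounds go, is how a phenyl carrying an amine or a carboxylic acid instead of halogens would behave in this assay.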